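The source may report more compounds than this note shows. Statements on the series, on what has been measured and on what is new or still open speak of the compounds shown alone.

For the measured compounds named here, compound 2, `Cc1cc(/C=C2\SC(=S)N(Cc3ccccc3)C2=O)c(C)n1-c1ccc(O)c(C(=O)O)c1`, is the only compound of this pair to give a number in an ADME assay on MT2 cells (Homo sapiens) for cytotoxicity, read by XTT assay, with a stated time of 4 days; on this read-out higher numbers stand for lower toxicity in this test and lower numbers for higher toxicity in this test: compound 2 gives 159000 nM. Compound 1, `Cc1cc(/C=C2\SC(=S)N(c3ccccc3)C2=O)c(C)n1-c1ccc(O)c(C(=O)O)c1`, gives in this assay only a limit, > 100000 nM. As far as these compounds go, the step that the limit leaves unreadable from compound 1 to compound 2 therefore cannot be read, because the limit of > 100000 nM in this assay, at which 1 of the 2 values shown sits, hides its size, so the effect of benzyl in place of phenyl on an amide-type nitrogen in a ring stays unknown here.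

Compound 3, `Cc1cc(/C=C2\SC(=S)N(Cc3ccc(C(F)(F)F)cc3)C2=O)c(C)n1-c1ccc(O)c(C(=O)O)c1`, is the next compound to be measured. It differs from compound 2 by trifluoromethyl in place of hydrogen on an aromatic carbon. No measured step in this assay bears on trifluoromethyl in place of hydrogen on an aromatic carbon; the one step shown is unreadable, so nothing in the data points in either direction. The account therefore expects for compound 3 a step of a 1.4-fold lower number from compound 2 to compound 3 (0.16 log units; within the scatter) that stays within the usual scatter of this assay. The estimate for compound 3 in this assay is 110000 nM, with a range from 45000 nM to 250000 nM, which awaits the measurement.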

Compound 3, half-maximal cytotoxic concentration: 45900 nM
Beside the measured number, compound 3's estimate is 2.4-fold (0.38 log units) above it, within the range that was stated.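

For the compounds shown here, this is the first readable step in this assay: a 3.5-fold lower number from compound 2 to compound 3 (0.54 log units; beyond the scatter) shows that trifluoromethyl in place of hydrogen on an aromatic carbon, para to a large group, moves the number beyond the scatter, towards higher toxicity in this test. The outer six-membered aromatic ring of the benzyl group is therefore a place where a change registers in this test, which the earlier pair, with its unreadable step, could not show. The other new step, an at least 2.1-fold lower number from compound 1 to compound 3 (0.33 log units; beyond the scatter), also lies beyond the scatter, but its size is only a lower bound, because of the following: the limit of > 100000 nM in this assay, at which 1 of the 3 values shown sits.

Whether this shift belongs to trifluoromethyl itself or would also appear with a chlorine atom, a methoxy group or a carboxylic acid at the same place stays open, as only one substituent on this ring is shown. Also open, as far as these compounds go, is how trifluoromethyl would act on the phenyl group of compound 1, or on a longer chain carrying the ring in place of benzyl.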